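Fluoro for methoxy on an aryl carbamate selenocyanate

The compounds below may be only part of what the source reports. "The series", "measured", "known", "first", "only" and "open" are said of these compounds alone.

Measured compounds:
- compound 1 `COc1ccc(OC(=O)Nc2ccc([Se]C#N)cc2)cc1`: 69600 nM
- compound 2 `CCCOC(=O)Nc1ccc([Se]C#N)cc1`: 75400 nM
- compound 3 `CCOC(=O)Nc1ccc([Se][Se]c2ccc(NC(=O)OCC)cc2)cc1`: 76100 nM

Of the compounds shown here, three have been measured in a functional assay on HT-29 cells (Homo sapiens) for cytotoxicity, read by MTT assay, with a stated time of 72 h; a higher number here means that more compound is tolerated, a lower number that less compound is tolerated. Compound 1 `COc1ccc(OC(=O)Nc2ccc([Se]C#N)cc2)cc1` gives 69600 nM in this assay. Compound 2 `CCCOC(=O)Nc1ccc([Se]C#N)cc1` gives 75400 nM, and compound 3 `CCOC(=O)Nc1ccc([Se][Se]c2ccc(NC(=O)OCC)cc2)cc1` gives 76100 nM. The gap from compound 1 to compound 2 lies within the scatter, as does the gap from compound 1 to compound 3, so compound 1 sits alongside the other two rather than apart from them. No two of these compounds differ in only one place, so no single step can be drawn between them.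

Compound 4 `N#C[Se]c1ccc(NC(=O)Oc2ccc(F)cc2)cc1` is not yet measured in this assay. It differs from compound 1 by fluoro in place of methoxy on an aromatic carbon, on an aromatic carbon of a six-membered aromatic ring of carbon only, para to a large group. With three quite different compounds all giving numbers close to one another in this assay, there is nothing in the data to suggest that this change would move the number beyond the scatter. The step from compound 1 to compound 4 is therefore expected to be a 1.0-fold higher number from compound 1 to compound 4 (0.01 log units; within the scatter). Compound 4 is estimated to give about 72000 nM in this assay, within a range from 35000 nM to 150000 nM.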

Compound 4, concentration lethal to 50% of the cells: 66500 nM
Beside the measured number, compound 4's estimate is 1.1-fold (0.03 log units) above it; measured number inside the range.
By their numbers in this assay, from the lowest: compounds 4, 1, 2 and 3 (each within the scatter of the next).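

In this assay, placing fluoro in the position of methoxy, on an aromatic carbon of a six-membered aromatic ring of carbon only and para to a large group, gives a 1.0-fold lower number from compound 1 to compound 4 (0.02 log units; within the scatter). Going by these compounds alone, this is the first step in the set that isolates a single place, since the earlier compounds differed in more than one place and could only be set side by side; here, the methoxy group and its oxygen give way to fluoro with the number remaining within the scatter. No measurement at hand accounts for this outcome.

A single pair cannot show whether this position accommodates other replacements in the same way, so an amine, a carboxylic acid or a longer alkoxy chain in that place might or might not leave the number within the scatter. Going by these compounds, it also remains open whether the same exchange of methoxy for fluoro would read alike on another carbon of that ring, or on a core other than that of compound 1.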